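Swapping the group on the ring nitrogen of compound 3

The source may hold more compounds than are shown below. What is called first, only, known or untested is meant among the compounds shown, and "the series" means these compounds.

In a functional assay on PANC-1 cells (Homo sapiens) for inhibition, read by XTT assay, with a stated time of 72 h (on this read-out lower numbers stand for stronger inhibition and higher numbers for weaker inhibition), compound 1 `CCCCCCCC/C=C/CCCCCCCCOC[C@@H]1CCCN1` gives 5300 nM. Compound 3 `Cc1ccc([S+]([O-])N2CCC[C@H]2COCCCCCC/C=C/c2ccc(Oc3ccccc3)cc2)cc1` gives 60000 nM, the higher of the two actual numbers in this small set. Compound 2 `Cc1ccc([S+]([O-])N2CCC[C@H]2COCCCCCC/C=C/c2ccc(-c3ccccc3)cc2)cc1` gives >= 100000 nM, which is a limit of the assay and not a number.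

Compound 4 `CC(C)(C)OC(=O)NCC(=O)N1CCC[C@H]1COCCCCCC/C=C/c1ccc(Oc2ccccc2)cc1` has not yet been measured. It departs from compound 3 at one place: a group of 11 heavy atoms (7 carbon, 1 nitrogen, 3 oxygen; no ring) in place of a group of 9 heavy atoms (7 carbon, 1 oxygen, 1 sulfur; one six-membered aromatic ring of carbon only), on an amine nitrogen in a ring. The entering group is (((tert-butoxycarbonyl)amino)methyl)carbonyl.

Going by the values given here, the only measured step, an at least 1.6-fold lower number from compound 2 to compound 3 (0.22 log units; that floor lies within the scatter), places phenoxy in place of phenyl on an aromatic carbon. Among the compounds with values here, that is a different place from the one changed here, so it offers only weak guidance, and no measured step covers this swap. Compound 3 at 60000 nM therefore remains the main anchor, and no step beyond the scatter is expected in this assay. The expected step is a 1.5-fold lower number from compound 3 to compound 4 (0.18 log units; within the scatter). For compound 4 the estimated value is 40000 nM, with an expected range from 10000 nM to 100000 nM.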

Compound 4, half-maximal inhibitory concentration: 63300 nM
Compound 4: the middle estimate sits 1.6-fold (0.20 log units) below what was measured; the measured number falls inside the stated range.
By their numbers in this assay, from the lowest: compound 1; then compounds 3 and 4 (each within the scatter of the next). At a limit, above all of these: compound 2.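

In this assay, going by these compounds alone, this is the first measured change on the amine nitrogen in the ring, and replacing the sulfur-bearing aromatic group with (((tert-butoxycarbonyl)amino)methyl)carbonyl gives a 1.1-fold higher number from compound 3 to compound 4 (0.02 log units; within the scatter). So, at this position, two groups that differ in atom count, in having a ring and in hydrogen-bond donors read the same within the scatter, which the earlier step on an aromatic carbon could not show. Compound 2 sits at a limit, not an actual number: the limit of >= 100000 nM in this assay, at which 1 of the 4 values shown sits.

From the compounds shown here alone, whether this position tolerates every group remains open, as both groups here are large. A free ring amine, an acetyl group or a free aminoacetyl group on the core of compound 3 would test whether a smaller group, or one carrying an amine, moves the number beyond the scatter.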